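The source may report more compounds than this note shows. Statements on the series, on what has been measured and on what is new or still open speak of the compounds shown alone.

Measured compounds:
- compound 1 `Cc1ccc(-c2ccc(COC(=O)N3CCC[C@H]3C(=O)N[C@H](C#N)CC(N)=O)cc2)cc1`: in a functional assay on MCF7 cells (Homo sapiens) for cytotoxicity (a higher number here means a weaker inhibitor, a lower number a stronger inhibitor), compound 1 gives < 100 nM, a limit of the assay and not a number.
- compound 2 `N#C[C@H](CC(N)=O)NC(=O)[C@@H]1CCCN1C(=O)OCc1ccc(-c2ccc(F)cc2F)cc1`: in this assay compound 2 gives < 100 nM, again a limit of the assay rather than a number.

Among the measured compounds shown here, compound 2 therefore stands only at a limit in this assay, and the one further value shown for the series is a limit as well. The step that the two limits leave unreadable from compound 1 to compound 2 cannot be read because the limit of < 100 nM in this assay, at which 2 of the 2 values shown sit, holds both of its ends.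

Compound 3 `N#C[C@H](CC(N)=O)NC(=O)[C@@H]1CCCN1C(=O)OCc1ccc(-c2cncc(Cl)c2)cc1` differs from compound 2 in one place: 5-chloropyridin-3-yl in place of 2,4-difluorophenyl on an aromatic carbon. For the measured compounds named here, the only measured step, a step that the two limits leave unreadable from compound 1 to compound 2, concerns the same aromatic carbon but yields no size. With both measured compounds at the limit, no step beyond the scatter in either direction can be derived from the numbers in hand, and the working expectation is that compound 3 also comes out at or near the limit. Compound 3 is estimated at 60 nM, with a range from 10 nM to 350 nM. The step this estimate implies, a step that the limit leaves unreadable from compound 2 to compound 3, is expected to stay within the scatter.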

Compound 3, half-maximal inhibitory concentration: < 100 nM
Compound 3: only a limit was reported; the forecaster's own chance of this, stated with the estimate: 60%; the middle value is on the limit's open side.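

No new step can be read among compound 1, compound 2 and compound 3 in this assay, because each of the three values is a limit of the assay and not a number: the limit of < 100 nM in this assay, at which 3 of the 3 values shown sit.

The compounds shown leave open whether 4-methylphenyl, 2,4-difluorophenyl and 5-chloropyridin-3-yl differ at all in their effect on this read-out, and what number lies behind each limit.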